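Replacing thiophen-3-yl with 3-methoxyphenyl: cytotoxicity notes

A few compounds are considered here, and "the series" means these few. Any claim that something is new, unique, unknown or untested is made for them only; others in the source may bear on it.

Three members of the series have been run in an ADME assay on HEK293 cells (Homo sapiens) for cytotoxicity, read by CellTiter-Glo and resazurin assay, with a stated time of 72 h; a higher number here means that more compound is needed for the effect, a lower number that less compound is needed. Compound 1 `CC(C)N(Cc1cccc(OCCCCCC(=O)O)c1)C(=O)c1ccc(-c2ccoc2)cc1` carries furan-3-yl on an aromatic carbon of the shared core; in this assay compound 1 gives > 26000 nM, a limit of the assay and not a number. Compound 2 `CC(C)Oc1cccc(-c2ccc(C(=O)N(Cc3cccc(OCCCCCC(=O)O)c3)C(C)C)cc2)c1` carries 3-isopropoxyphenyl at that carbon; in this assay compound 2 gives > 26000 nM, again only a limit. Compound 3 `CC(C)N(Cc1cccc(OCCCCCC(=O)O)c1)C(=O)c1ccc(-c2ccsc2)cc1` carries thiophen-3-yl; in this assay compound 3 gives > 26000 nM, likewise a limit. Compound 3 thus stands at the limit, and the other two measured values sit at the same limit, so no order among the three can be read. The steps a step that the two limits leave unreadable from compound 1 to compound 2, a step that the two limits leave unreadable from compound 1 to compound 3 and a step that the two limits leave unreadable from compound 2 to compound 3 all remain unreadable because of the limit of > 26000 nM in this assay, at which 3 of the 3 values shown sit.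

Compound 4 `COc1cccc(-c2ccc(C(=O)N(Cc3cccc(OCCCCCC(=O)O)c3)C(C)C)cc2)c1` is not yet measured. It differs from compound 3 by 3-methoxyphenyl in place of thiophen-3-yl on an aromatic carbon. Going by the values given here, all three measured steps exchange the group at this same carbon, and none of them produced a readable size; the exchange into 3-isopropoxyphenyl in compound 2 is the nearest precedent, and it too ended at the limit. The step that the limit leaves unreadable from compound 3 to compound 4 is therefore expected to be none beyond the scatter. Compound 4 is estimated at 40000 nM, with a range from 20000 nM to 100000 nM, and is expected most likely to be reported as a limit once more.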

Compound 4, half-maximal effective concentration: > 20900 nM
Compound 4: only a limit was reported; the forecaster's own chance of this, stated with the estimate: 85%; the middle value does not contradict the limit.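

In this assay compound 4 gives > 20900 nM, a limit of the assay and not a number. The steps joining compound 4 to compound 1, compound 2 and compound 3 cannot be read, because each ends at a limit: the limit of > 20900 nM in this assay, at which 1 of the 4 values shown sits.

The compounds shown leave open whether exchanging the group on this aromatic carbon changes cytotoxicity at all.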